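Half-life series: heteroaryl sulfanyl versus pivaloyloxy on the core

The source may hold more compounds than are shown below. What is called first, only, known or untested is meant among the compounds shown, and "the series" means these compounds.

Compound 3 `CO[C@H]1C(=O)N2C(C(=O)C(C)(C)C)=C(C)[C@@H](OC(=O)C(C)(C)C)S(=O)(=O)C12` holds the highest number of the three measured in a physicochemical assay, at pH 7.4 (a lower number here means that the compound disappears faster, a higher number that the compound lasts longer), giving 54 h. Compound 1 `CO[C@H]1C(=O)N2C(C(=O)C(C)(C)C)=C(C)[C@@H](Sc3nnnn3C)S(=O)(=O)C12` gives 18 h and compound 2 `CO[C@H]1C(=O)N2C(C(=O)C(C)(C)C)=C(C)[C@@H](Sc3nnc(C)s3)S(=O)(=O)C12` gives 27 h in this assay. Compound 4 `CO[C@H]1C(=O)N2C(C(=O)C(C)(C)C)=C(C)[C@@H](Sc3ccccn3)S(=O)(=O)C12` carries (pyridin-2-yl)sulfanyl in place of ((tert-butyl)carbonyl)oxy on a saturated ring carbon. Going by the values given here, the steps that bear on this change run the other way: a 3.0-fold higher number from compound 1 to compound 3 (0.48 log units; beyond the scatter) and a 2.0-fold higher number from compound 2 to compound 3 (0.30 log units; within the scatter), while a 1.5-fold higher number from compound 1 to compound 2 (0.18 log units; within the scatter) shows the two heteroaryl sulfanyl groups close to each other. Returning to a heteroaryl sulfanyl group is therefore expected to bring the number back toward compounds 1 and 2, an estimated step of a 2.3-fold lower number from compound 3 to compound 4 (0.35 log units; beyond the scatter). For compound 4 the expected value is 24 h, within a range of 12 h to 48 h.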

Compound 4, half-life: 24 h
The estimate for compound 4 equals the measured number at the digits printed, within the range that was stated.
By their numbers in this assay, from the lowest: compounds 1, 4, 2 and 3 (each within the scatter of the next, the first and the last beyond it).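

In this assay, (pyridin-2-yl)sulfanyl in place of ((tert-butyl)carbonyl)oxy on this saturated ring carbon gives a 2.3-fold lower number from compound 3 to compound 4 (0.35 log units; beyond the scatter) and so extends the gap to a third heteroaryl sulfanyl group. The heteroaryl group on the sulfur has little bearing here, with a 1.1-fold lower number from compound 2 to compound 4 (0.05 log units; within the scatter) and a 1.3-fold higher number from compound 1 to compound 4 (0.12 log units; within the scatter) as the two steps, so a six-membered aromatic ring fits with the tetrazolyl and thiadiazolyl groups. No available data account for this result.

Open, on these data alone, is whether this level follows the sulfur link or the heteroaryl ring. A phenylsulfanyl group, an alkylsulfanyl chain or an amine on this carbon would separate the two.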